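Cytotoxicity of compound 4 judged from three measured analogues

A few compounds are considered here, and "the series" means these few. Any claim that something is new, unique, unknown or untested is made for them only; others in the source may bear on it.

Compound 1 `COc1ccc(F)cc1CNCCCNc1ccnc2cc(Cc3ccc(F)cc3Cl)ccc12` gives 2460 nM in an ADME assay on HepG2 cells (Homo sapiens) for cytotoxicity, read by luminescence, CellTiter-Glo and ATP content, with a stated time of 72 h (on this read-out lower numbers stand for an effect already at smaller amounts and higher numbers for an effect only at larger amounts of compound), the lowest of the three numbers in hand. Compound 3 `COc1ccc(F)cc1CNCCCNc1ccnc2cc(CCc3ccccc3)ccc12` gives 4240 nM; compound 2 `CCC(CC)c1ccc2c(NCCCNCc3cc(F)ccc3OC)ccnc2c1` gives 7860 nM. The steps of a 1.7-fold higher number from compound 1 to compound 3 (0.24 log units; within the scatter) and a 3.2-fold higher number from compound 1 to compound 2 (0.50 log units; beyond the scatter) both change the group on the shared core, not the benzylamine end. Compound 4 `COc1cccc(CNCCCNc2ccnc3cc(Cc4ccc(F)cc4Cl)ccc23)c1O` differs from compound 1 at that other end: 2-hydroxy-3-methoxyphenyl in place of 5-fluoro-2-methoxyphenyl on a saturated chain carbon bound to an amine nitrogen. Within the data shown here, no measured step touches this position, so the only guide is that the three numbers lie close together. A shift no larger than the scatter is therefore expected, a 1.2-fold higher number from compound 1 to compound 4 (0.09 log units; within the scatter). Compound 4 is estimated at 3000 nM, with a range from 1200 nM to 7500 nM.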

Compound 4, half-maximal effective concentration: 2350 nM
For compound 4 the middle estimate is 1.3-fold (0.11 log units) above the measured one; the range from low to high includes it.
By their numbers in this assay, from the lowest: compounds 4, 1, 3 and 2 (each within the scatter of the next, the first and the last beyond it).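

In this assay, among these compounds, the first measured change at this end of the molecule gives a 1.0-fold lower number from compound 1 to compound 4 (0.02 log units; within the scatter) with the 2-chloro-4-fluorobenzyl group kept on the shared core. Exchanging 5-fluoro-2-methoxyphenyl for 2-hydroxy-3-methoxyphenyl removes the fluorine and adds a hydrogen-bond donor and a hydrogen-bond acceptor, yet the step stays within the scatter. Nothing available explains this outcome. Going by these compounds, it remains open whether a carboxylic acid or a cyclohexyl group in place of 2-hydroxy-3-methoxyphenyl would give a step beyond the scatter, and whether the same exchange behaves alike with pentan-3-yl or phenethyl on the shared core.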